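This account rests on a few compounds, and the source may have more. Where it says the series, first, only, none or still open, it means among the compounds named here.

Values in a functional assay on MCF7 cells (Homo sapiens) for cytotoxicity, read by MTT assay, with a stated time of 96 h (on this read-out lower numbers stand for stronger inhibition and higher numbers for weaker inhibition), for the compounds measured so far

Compound 1 `COc1cc(C(=O)c2cn(-c3cccc(C)c3)cc2-c2ccccc2[N+](=O)[O-])cc(OC)c1OC` gives 220 nM
Compound 2 `COc1cc(C(=O)c2cn(-c3cccc(N)c3)cc2-c2ccccc2[N+](=O)[O-])cc(OC)c1OC` gives 14 nM

Among the measured compounds shown here, compound 2 has the lower of these two numbers, and its only neighbour is compound 1 at 220 nM on this scale. The change to compound 3 `COc1cc(C(=O)c2cn(-c3ccc(C)cc3)cc2-c2ccccc2[N+](=O)[O-])cc(OC)c1OC` is 4-methylphenyl in place of 3-aminophenyl on an aromatic nitrogen, counted as 4-methylphenyl in place of 3-aminophenyl on an aromatic nitrogen on the shared core. For the measured compounds named here, the one measured step that bears on it is a 16-fold lower number from compound 1 to compound 2 (1.20 log units; beyond the scatter) for amino in place of methyl on an aromatic carbon, a large step beyond the scatter. Going by the values given here, compound 3 has no amino group and carries a methyl, as compound 1 does, though no measured pair shows what the place of that methyl on the ring does. A large step of similar size toward a higher number is therefore expected in this assay for this change. The expected change is a 13-fold higher number from compound 2 to compound 3 (1.11 log units; beyond the scatter) in this estimate. Compound 3 is expected at 180 nM with an estimated range of 50 nM to 600 nM on this read-out.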

Compound 3, half-maximal inhibitory concentration: 65 nM
For compound 3 the middle estimate is 2.8-fold (0.44 log units) above the measured one, and the stated range covers the measured number.
By their numbers in this assay, from the lowest: compound 2; then compound 3; then compound 1.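

In this assay, the place of the methyl on the ring matters on its own: 4-methylphenyl in place of 3-methylphenyl on the aromatic nitrogen gives a 3.4-fold lower number from compound 1 to compound 3 (0.53 log units; beyond the scatter), which the earlier pair could not show. An amino group is therefore not needed to bring the number down from that of compound 1, although the 3-aminophenyl group still holds the lowest number of the three, with a 4.6-fold higher number from compound 2 to compound 3 (0.67 log units; beyond the scatter). That last step changes both the group and its place on the ring, so it cannot be split between the two. Nothing at hand gives a reason for either step.

The compounds shown leave open whether an amino group would do better or worse standing where the methyl of compound 3 stands. They also leave open how a hydroxyl or a methoxy group on this ring would compare.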